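Dodecyl tetrazole acetanilides: methoxy to dimethylamino on the aryl

This account rests on a few compounds, and the source may have more. Where it says the series, first, only, none or still open, it means among the compounds named here.

Measured compounds:
compound 1, `CCCCCCCCCCCCn1nnc(C(C(=O)Nc2ccc(F)cc2F)c2ccccc2)n1`, 31 nM
compound 2, `CCCCCCCCCCCCn1nnc(C(C(=O)Nc2c(OC)cc(OC)cc2OC)c2ccc(OC)cc2)n1`, 200 nM

Both were tested in an assay on liver for inhibition of sterol O-acyltransferase 1 (Rattus norvegicus), using microsomes; on this read-out higher numbers stand for weaker inhibition and lower numbers for stronger inhibition. Compound 1 carries a difluorophenyl amide and an unsubstituted phenyl and gives 31 nM. Compound 2, with a trimethoxyphenyl amide and a 4-methoxyphenyl group, gives 200 nM; of the two numbers this is the higher one, and the gap to compound 1 lies beyond the scatter. The two compounds differ in more than one place, so nothing is said about which change carries that gap.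

Compound 3, `CCCCCCCCCCCCn1nnc(C(C(=O)Nc2c(OC)cc(OC)cc2OC)c2ccc(N(C)C)cc2)n1`, has not been measured. It differs from compound 2 in one place: dimethylamino in place of methoxy on an aromatic carbon. Methoxy and dimethylamino both count as one hydrogen-bond acceptor and no donor, and the group sits on the same aromatic carbon. Among the measured compounds shown here, nothing among the measured compounds shows what such an exchange does here, so no step beyond the scatter is expected in either direction, and the range is kept wide. The expected step is a 1.3-fold higher number from compound 2 to compound 3 (0.10 log units; within the scatter). Compound 3 is estimated at 250 nM, with a range from 80 nM to 800 nM.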

Compound 3, half-maximal inhibitory concentration: 659 nM
Estimate against measurement, compound 3: 2.6-fold (0.42 log units) below; the measured number falls inside the stated range.
By their numbers in this assay, from the lowest: compound 1; then compound 2; then compound 3.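

In this assay, among the compounds shown here, the exchange of 4-methoxyphenyl for 4-(dimethylamino)phenyl provides the only single-place comparison so far, with a 3.3-fold higher number from compound 2 to compound 3 (0.52 log units; beyond the scatter). The position para to a large group is therefore not indifferent to this exchange, and inhibition weakens even though methoxy and dimethylamino have the same count of hydrogen-bond donors and acceptors. The entering group is larger by one heavy atom and replaces oxygen with nitrogen, but no measurement shown here separates these differences or bears on why the number rises.

As far as these compounds go, it remains open whether the step is specific to dimethylamino or would also appear with other groups on this aromatic carbon, such as a primary amine, a fluorine, or a hydrogen as in the unsubstituted phenyl of compound 1. Compound 1 differs from compound 2 and compound 3 in more than one place, so the contribution of its phenyl cannot be read from these data, and the same holds for the amide aryl groups; a single change from the dodecyl chain to a shorter alkyl chain would also be untested here.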